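The compounds below may be only part of what the source reports. "The series", "measured", "known", "first", "only" and "open" are said of these compounds alone.

Compound 1, whose structure is `COc1ccc(-c2cc(/C=C/C(=O)c3ccc(N)cc3)[nH]n2)cc1`, is one of three compounds examined in a functional assay on HCT-116 cells (Homo sapiens) for cytotoxicity, read by sulforhodamine B assay, with a stated time of 48 h, tested at 10 uM; a higher number here means a weaker effect of the compound at the concentration tested, a lower number a stronger effect. In this assay compound 1 gives -53%, the second highest of the three numbers. Compound 2, with structure `COc1ccc(C(=O)/C=C/c2cc(-c3cc(OC)c(OC)c(OC)c3)n[nH]2)cc1OC`, sits nearest, giving -65%, a number below that of compound 1 and beyond the scatter. Compound 3, with structure `COc1ccc(C(=O)/C=C/c2cc(-c3cc(OC)c(OC)c(OC)c3)n[nH]2)cc1`, stands furthest away and gives -22%.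

Compound 4, with structure `COc1ccc(-c2cc(/C=C/C(=O)c3ccc(N)cc3)[nH]n2)cc1OC`, has not yet been measured in this assay. It differs from compound 1 by methoxy in place of hydrogen on an aromatic carbon. The entering methoxy sits on an aromatic carbon of a six-membered aromatic ring of carbon only, ortho to a methoxy group and meta to a large group.

For the measured compounds named here, one measured step bears on this change, in the opposite direction: a number 43 percentage points higher from compound 2 to compound 3 (beyond the scatter). That step was large, so the reverse change, methoxy in place of hydrogen on an aromatic carbon, is expected to lower the number for compound 4 relative to compound 1, though the shared core around the changed ring differs between the two pairs, so the step is expected to be somewhat smaller than a number 43 percentage points higher from compound 2 to compound 3 (beyond the scatter), namely a number 27 percentage points lower from compound 1 to compound 4 (beyond the scatter). Compound 4 is therefore estimated to give -80% in this assay, with a range from -100% to -50%.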

Compound 4, a percentage reported as activity, at one concentration (the size of the read-out at that concentration, not a potency): -73%
Estimate against measurement, compound 4: 7 percentage points below, and the stated range covers the measured number.
By their numbers in this assay, from the lowest: compounds 4 and 2 (each within the scatter of the next); then compound 1; then compound 3.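

In this assay, methoxy in place of hydrogen on an aromatic carbon, ortho to a methoxy group and meta to a large group, comes with a number 20 percentage points lower from compound 1 to compound 4 (beyond the scatter), so the direction of the earlier reverse step also holds on the core of compound 1. The earlier compounds shown here showed this change on a single core only, and could not tell whether its size would carry over to another core. Direction and size now part ways, with the same sign on both cores but a size that depends on the core: the same change on two cores in this assay, a number 43 percentage points higher (beyond the scatter) from compound 2 to compound 3 and a number 20 percentage points higher (beyond the scatter) from compound 4 to compound 1, 23 percentage points apart, beyond the scatter of two such steps

The compounds shown leave open whether another group at this place, such as a hydroxyl, an ethoxy or a fluorine, would lower the number as methoxy does, as only hydrogen and methoxy are compared here. On these data alone, they also cannot tell what sets the size of the step on each core, and with one pair per core, how large the step would be on a third core remains unknown.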